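The source may report more compounds than this note shows. Statements on the series, on what has been measured and on what is new or still open speak of the compounds shown alone.

The shared core is that of compound 1 `O=C1c2c[n+]([O-])c3ccccc3c2C(=O)c2c1c1ccccc1n2CCCCn1ccnc1`. In a functional assay on MDA-MB-231 cells (Homo sapiens) for cytotoxicity, read by MTT assay, with a stated time of 72 h (on this read-out higher numbers stand for weaker inhibition and lower numbers for stronger inhibition), compound 1 gives 210 nM, the lower of the two numbers recorded. Compound 2 `O=C1c2c[n+]([O-])c3ccccc3c2C(=O)c2c1c1ccccc1n2Cc1cn(CC(O)CO)nn1` gives 1290 nM in this assay. Compound 3 `CC1(C)OC[C@@H](Cn2cc(Cn3c4c(c5ccccc53)C(=O)c3c[n+]([O-])c5ccccc5c3C4=O)nn2)O1` is reported in this assay only as a limit, > 1000 nM. Within the data shown here, the one readable step is a 6.1-fold higher number from compound 1 to compound 2 (0.79 log units; beyond the scatter). It concerns a change other than the one now in question. The step that the limit leaves unreadable from compound 2 to compound 3 cannot be sized because of the limit of > 1000 nM in this assay, at which 1 of the 3 values shown sits.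

Compound 4 `CN1CCN(CCCn2c3c(c4ccccc42)C(=O)c2c[n+]([O-])c4ccccc4c2C3=O)CC1` differs from compound 1 in a single place: 4-methylpiperazin-1-yl in place of (1H-imidazol-1-yl)methyl on a saturated chain carbon, three bonds along the chain from an aromatic nitrogen. Among the measured compounds shown here, none of the measured steps exchanges one chain-borne ring for another of this kind, so no measured step bears directly on it, and the closest comparison, compound 1 against compound 2, concerns a different replacement. The account therefore expects no step beyond the scatter, a 1.4-fold higher number from compound 1 to compound 4 (0.15 log units; within the scatter). Compound 4 is estimated in this assay at 300 nM, with a range from 100 nM to 1000 nM.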

Compound 4, half-maximal inhibitory concentration: 390 nM
Estimate against measurement, compound 4: 1.3-fold (0.11 log units) below; measured number inside the range.
By their numbers in this assay, from the lowest: compounds 1 and 4 (each within the scatter of the next); then compound 2.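

In this assay, the exchange at this position gives a 1.9-fold higher number from compound 1 to compound 4 (0.27 log units; within the scatter), so on this read-out a six-membered non-aromatic ring in 4-methylpiperazin-1-yl cannot be told apart from the five-membered aromatic ring in (1H-imidazol-1-yl)methyl, on a saturated chain carbon, three bonds along the chain from an aromatic nitrogen. The second new comparison gives a 3.3-fold lower number from compound 2 to compound 4 (0.52 log units; beyond the scatter), which shows that the 2-(4-methylpiperazin-1-yl)ethyl group differs measurably from the 1-(2,3-dihydroxypropyl)-1H-1,2,3-triazol-4-yl group, as the imidazole-bearing chain of compound 1 already did. Nothing recorded here accounts for these numbers.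

The compounds shown leave open whether a morpholin-4-yl ring or an open-chain dimethylamino group at the same place would also stay within the scatter of compound 1. They also leave open how a longer chain carrying 4-methylpiperazin-1-yl would read.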